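Moving a Hydroxyl Group on a Pyridine-Linked Phenol

The source may report more compounds than this note shows. Statements on the series, on what has been measured and on what is new or still open speak of the compounds shown alone.

Compound 1 `Oc1ccc(-c2cc(-c3ccco3)cc(-c3cccc(O)c3)n2)cc1` and compound 2 `Oc1ccc(-c2cc(-c3cccnc3)cc(-c3ccccc3O)n2)cc1` share a core that carries a 4-hydroxyphenyl group. In a functional assay on T47D cells (Homo sapiens) for cytotoxicity, read by CCK-8 assay (on this read-out lower numbers stand for stronger inhibition and higher numbers for weaker inhibition), compound 1 gives 1280 nM. For compound 2 this assay reports only a limit, > 50000 nM, so compound 2 sits at the limit of > 50000 nM in this assay, at which 1 of the 2 values shown sits. Compound 3 `Oc1ccc(-c2cc(-c3cccnc3)cc(-c3cccc(O)c3)n2)cc1` differs from compound 2 by 3-hydroxyphenyl in place of 2-hydroxyphenyl on an aromatic carbon, the group that compound 1 also carries. The expected step here is an at least 8.3-fold lower number from compound 2 to compound 3 (0.92 log units; beyond the scatter), toward stronger inhibition. Compound 3 is expected to give about 6000 nM, with a likely range from 1200 nM to 50000 nM.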

Compound 3, half-maximal inhibitory concentration: > 50000 nM
Compound 3 ended at the assay's limit; the forecaster's own chance of this, stated with the estimate: 35%; middle value at least 8.3-fold (0.92 log units) from the limit.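

In this assay, the change from 2-hydroxyphenyl to 3-hydroxyphenyl cannot be judged, and the step between compound 2 and compound 3 cannot be read because both values are limits: the limit of > 50000 nM in this assay, at which 2 of the 3 values shown sit.

The comparison that can be read concerns the other position: with 3-hydroxyphenyl kept, pyridin-3-yl in place of furan-2-yl gives an at least 39-fold higher number from compound 1 to compound 3 (1.59 log units; beyond the scatter), toward weaker inhibition.

Still open, from the compounds shown here alone, is how 2-hydroxyphenyl behaves when paired with furan-2-yl. Also open, going by these compounds, is whether an amine or a carboxylic acid in place of pyridin-3-yl would bring inhibition back into a readable range.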